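Swapping bromo for trifluoromethyl on the shared core

A few compounds are considered here, and "the series" means these few. Any claim that something is new, unique, unknown or untested is made for them only; others in the source may bear on it.

compound 1 `CCC(=O)N(c1cccc(F)c1)C1CCCC1N(C)C` gives 0.4 mg/kg as its value
compound 2 `CCC(=O)N(c1cccc(Br)c1)C1CCCC1N(C)C` gives 0.1 mg/kg as its value

In a functional assay on the whole organism for positive allosteric modulation, with Mus musculus as the target (a lower number here means that less compound is needed, a higher number that more compound is needed for the effect), compound 2 holds the lower of the two numbers. Compound 3 `CCC(=O)N(c1cccc(C(F)(F)F)c1)C1CCCC1N(C)C` differs from it by trifluoromethyl in place of bromo on an aromatic carbon and has trifluoromethyl in place of bromo on an aromatic carbon. Among the compounds with values here, only one measured step bears on this, a 4.0-fold lower number from compound 1 to compound 2 (0.60 log units; beyond the scatter) for bromo in place of fluoro, and it lies beyond the scatter. It does not involve trifluoromethyl, so it sets no firm direction. A move beyond the scatter is therefore not expected, and the estimated change is a 1.5-fold higher number from compound 2 to compound 3 (0.18 log units; within the scatter) on this reading. For compound 3 the estimate is 0.15 mg/kg with an expected range from 0.05 mg/kg to 0.5 mg/kg in repeated measurements.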

Compound 3, dose for half-maximal effect: 0.3 mg/kg
Beside the measured number, compound 3's estimate is 2.0-fold (0.30 log units) below it, and the stated range covers the measured number.
By their numbers in this assay, from the lowest: compound 2; then compounds 3 and 1 (each within the scatter of the next).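

Bromo stands apart from both fluoro and trifluoromethyl at this place on the aromatic ring in this assay. Changing bromo to trifluoromethyl gives a 3.0-fold higher number from compound 2 to compound 3 (0.48 log units; beyond the scatter) and so loses much of what bromo gained, whereas changing fluoro to trifluoromethyl gives a 1.3-fold lower number from compound 1 to compound 3 (0.12 log units; within the scatter). No supporting measurement bears on why these groups differ. On these data alone, it remains open whether chloro, iodo, methyl or methoxy at this place would match bromo, and whether the advantage of bromo would survive a change elsewhere on the shared core.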